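The compounds below may be only part of what the source reports. "The series", "measured", "known", "first", "only" and "open" are said of these compounds alone.

Measured compounds:
Compound 1, `COc1cc2c(Nc3nc4ccc(C(=O)Nc5c(C)cccc5Cl)cc4s3)ncnc2cc1OCCCN1CCCCC1C`, gives 7000 nM in a functional assay on U-937 cells (Homo sapiens) for cytotoxicity, read by WST assay, with a stated time of 72 h; on this read-out lower numbers stand for stronger inhibition and higher numbers for weaker inhibition.
Compound 2, `COc1cc2c(Nc3nc4ccc(C(=O)Nc5c(C)cccc5C)cc4s3)ncnc2cc1OCCCN1CCCC1`, gives 18900 nM in this assay.
Compound 3, `COc1cc2c(Nc3nc4ccc(C(=O)Nc5c(C)cccc5C)cc4s3)ncnc2cc1OCCCN1CCCCC1`, gives 14700 nM in this assay.

Among these three numbers compound 3 stands second highest. Its nearest neighbour is compound 2, whose number lies within the scatter of repeated measurements, so no order can be read between the two; compound 1 gives a number that is lower than that of compound 3 by more than the scatter. Compound 4, `COc1cc2c(Nc3nc4ccc(C(=O)Nc5c(C)cccc5C)cc4s3)ncnc2cc1OCCCN1CCCCC1C`, is not yet measured. It differs from compound 3 in one place: methyl in place of hydrogen on a saturated ring carbon. For the measured compounds named here, the only measured step, a 1.3-fold lower number from compound 2 to compound 3 (0.11 log units; within the scatter), exchanges one ring for another on the same chain and does not test a methyl added to that ring; it shows only that a change at this end of the molecule stayed small. Compound 1 carries the same methylated ring as compound 4, but it also differs from compound 3 at the amide end, so its lower number cannot be credited to the methyl alone. Compound 4 is therefore expected to lie close to compound 3, with at most a modest move toward a lower number, an expected step of a 1.5-fold lower number from compound 3 to compound 4 (0.17 log units; within the scatter) in this assay. The estimate for compound 4 is 10000 nM, with a range from 4000 nM to 25000 nM.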

Compound 4, half-maximal inhibitory concentration: 10800 nM
For compound 4 the middle estimate is 1.1-fold (0.03 log units) below the measured one, and the stated range covers the measured number.
By their numbers in this assay, from the lowest: compounds 1, 4, 3 and 2 (each within the scatter of the next, the first and the last beyond it).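

In this assay, for the compounds shown here, the methyl on a saturated ring carbon, next to the ring nitrogen, is tested on its own for the first time and gives a 1.4-fold lower number from compound 3 to compound 4 (0.13 log units; within the scatter), so no effect of this methyl can be read. The larger exchange of pyrrolidin-1-yl for 2-methylpiperidin-1-yl gives a 1.8-fold lower number from compound 2 to compound 4 (0.24 log units; within the scatter), and methyl in place of chloro on an aromatic carbon, now seen as a single change at the amide end, gives a 1.5-fold higher number from compound 1 to compound 4 (0.19 log units; within the scatter), so none of these three changes separates its pair beyond the scatter. Nothing shown here explains why these steps stay so small.

Still open, going by these compounds, is whether a morpholin-4-yl ring or a dimethylamino group at the end of the same chain would shift the number more clearly. Also open, on these data alone, is what a shorter or longer chain would do, or a methoxy group on the aromatic ring of the amide.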